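The source may report more compounds than this note shows. Statements on the series, on what has been measured and on what is new or still open speak of the compounds shown alone.

Measured in a functional assay for inhibition, with Homo sapiens as the target; a lower number here means that less compound is needed, a higher number that more compound is needed for the effect:
- compound 1 `CCCC(=O)Nc1ccc(C2=NNC(=O)CC2)cc1`: 1.44 ug/mL
- compound 2 `CC(=O)Nc1ccc(C2=NN(C)C(=O)CC2)cc1`: > 46.4 ug/mL
- compound 3 `Nc1cccc(C2=NNC(=O)CC2)c1`: > 46.4 ug/mL

Not yet measured: compound 4 `CC(C)NCC(=O)Nc1ccc(C2=NNC(=O)CC2)cc1`

Going by the values given here, compound 1 is the only compound here with an actual number, 1.44 ug/mL. Compound 2 gives > 46.4 ug/mL, which is a limit and not a number. Compound 3 gives > 46.4 ug/mL, which is also a limit.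

Compound 4 keeps the core of compound 1, but isopropylamino stands in place of ethyl on a saturated chain carbon bound to a carbonyl carbon: isopropylamino in place of ethyl on a saturated chain carbon bound to a carbonyl carbon.

Among the compounds with values here, no measured step covers this change, and compound 1 at 1.44 ug/mL is the sole starting point. A moderate move beyond the scatter is therefore expected in this assay, towards more compound being needed. The expected step is a 4.2-fold higher number from compound 1 to compound 4 (0.62 log units; beyond the scatter). For compound 4 the estimate is 6 ug/mL, with an expected range from 1 ug/mL to 40 ug/mL.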

Compound 4, half-maximal effective concentration: about 46.4 ug/mL
Compound 4: the middle estimate sits 7.7-fold (0.89 log units) below what was measured, outside the stated range (above it).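

In this assay, isopropylamino in place of ethyl on a saturated chain carbon bound to a carbonyl carbon gives a 32-fold higher number from compound 1 to compound 4 (1.51 log units; beyond the scatter). This first measured step at this position shows that, with the shared core unchanged, far more compound is needed once this group is present. The value of compound 4 falls at the same figure as a limit of this assay: the limit of > 46.4 ug/mL in this assay, at which 2 of the 4 values shown sit.

Whether the nitrogen or the branched isopropyl end accounts for the change stays open. A plain propyl or a dimethylamino group in place of ethyl would help separate the two.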